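This account rests on a few compounds, and the source may have more. Where it says the series, first, only, none or still open, it means among the compounds named here.

Measured so far:
compound 1 `O=C(O)CC/C=C\CO[C@H]1C(OCc2ccc(-c3ccc(CO)cc3)cc2)CC[C@@H]1N1CCCCCC1` — 3.16 nM
compound 2 `O=C(O)CC/C=C\CO[C@H]1[C@H](OCc2ccc(-c3ccccc3CO)cc2)CC[C@@H]1N1CCCCCC1` — 6.31 nM

Both numbers come from a functional assay on blood for antagonist activity at thromboxane A2 receptor (Homo sapiens); on this read-out lower numbers stand for tighter binding and higher numbers for weaker binding. Compound 1 gives the smaller of the two readings, but compound 2 sits within the usual scatter of it, so the pair cannot be ordered with confidence.

Compound 3 `O=C(O)CC/C=C\CO[C@H]1C(OCc2ccc(-c3ccccc3CO)cc2)CC[C@@H]1N1CCCCCC1` is not yet measured. It differs from compound 1 in one place: 2-(hydroxymethyl)phenyl in place of 4-(hydroxymethyl)phenyl on an aromatic carbon. Among the measured compounds shown here, no measured pair isolates this change, so its size is not known from a step. What the data show is that compound 2, which carries the same 2-(hydroxymethyl)phenyl group on an otherwise matching framework, reads 6.31 nM. On that basis the step from compound 1 to compound 3 is expected to be small, if anything toward a somewhat higher number, and likely within the scatter: a 1.6-fold higher number from compound 1 to compound 3 (0.20 log units; within the scatter). Compound 3 is estimated at 5 nM, with a range of 2 nM to 12 nM.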

Compound 3, dissociation constant: 3.16 nM
Compound 3: middle estimate off by 1.6-fold (0.20 log units), on the high side; low and high end bracket the measured number.
By their numbers in this assay, from the lowest: compounds 1, 3 and 2 (each within the scatter of the next).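

In this assay the swap of 4-(hydroxymethyl)phenyl for 2-(hydroxymethyl)phenyl now has a step of its own, showing no change at the digits printed from compound 1 to compound 3 (within the scatter) and so no separation of the two groups at this place on the aromatic ring. The second new pair shows a 2.0-fold lower number from compound 2 to compound 3 (0.30 log units; within the scatter) and gives no firm reading on configuration at the saturated ring carbon. Among the compounds shown here, the only difference behind that step is a matter of how the stereocentre is drawn: the fact that one of compounds 2 and 3 is drawn with a defined configuration and the other without, at the place where they differ.

From the compounds shown here alone, whether the insensitivity to this change extends to other groups on the same aromatic ring, such as a carboxylic acid or an amine in place of hydroxymethyl, stays open. Also open, going by these compounds, is how a form drawn with the opposite configuration at that ring carbon would read in this assay on this framework.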